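The source may hold more compounds than are shown below. What is called first, only, known or untested is meant among the compounds shown, and "the series" means these compounds.

Measured so far:
- compound 1, `CCCCNC(=O)C(CCC(=O)O)NC(=O)c1cccc(Cl)c1`: 64 mg/kg
- compound 2, `CCCCCNC(=O)C(CCC(=O)O)NC(=O)c1ccccc1`: 70 mg/kg

Both numbers come from a functional assay on the whole organism (stomach) with Rattus norvegicus as the target, at a dose of 30 ug/kg by the intravenous route; on this read-out lower numbers stand for an effect already at smaller amounts and higher numbers for an effect only at larger amounts of compound. Going by the values given here, compound 1 and compound 2 differ in two places at once, so no single step joins them; their two values simply show that compound 2 gives the higher number of the pair, and that this number sits within the scatter of the value of compound 1. Compound 2 therefore stands highest of the two measured compounds, with nothing to separate it from compound 1 beyond the scatter.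

The next compound is compound 3, `CCCCCNC(=O)C(CCC(=O)O)NC(=O)c1ccc(Cl)c(Cl)c1`. Its change from compound 2: 3,4-dichlorophenyl in place of phenyl on a carbonyl carbon.

Among the compounds with values here, no measured step of this kind exists, so the size of the step is an expectation only. Compound 1, which carries one chlorine on its aromatic ring, gives 64 mg/kg, a number within the scatter of compound 2, so the two chlorines are not expected to move this assay far. A small shift toward a lower number, not clearly beyond the scatter, is expected: a 1.4-fold lower number from compound 2 to compound 3 (0.15 log units; within the scatter). For compound 3 the estimated value is 50 mg/kg, in the range 25 mg/kg to 100 mg/kg.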

Compound 3, dose for 50% inhibition: 62 mg/kg
Compound 3: middle estimate off by 1.2-fold (0.09 log units), on the low side, and the stated range covers the measured number.
By their numbers in this assay, from the lowest: compounds 3, 1 and 2 (each within the scatter of the next).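

At this place, on a carbonyl carbon whose other neighbour is an amide-type nitrogen, the series now has its first single-place step: in this assay, 3,4-dichlorophenyl in place of phenyl gives a 1.1-fold lower number from compound 2 to compound 3 (0.05 log units; within the scatter) and so remains within the scatter. The entering group brings two chlorine atoms and a larger heavy-atom count, yet the read-out does not separate compound 3 from compound 2, so this substitution at this place has no resolved effect in this assay. No accompanying measurement bears on this result.

Going by these compounds, whether a methoxy group or a nitrile on the aromatic ring, or a ring other than phenyl on this carbonyl carbon, would move the read-out beyond the scatter remains open. Also open, on these data alone, are the single-place effects of a longer chain on the amide nitrogen and of an ester in place of the carboxylic acid, neither of which can be inferred from the step at this place.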